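This account rests on a few compounds, and the source may have more. Where it says the series, first, only, none or still open, it means among the compounds named here.

Two compounds of a shared core, each carrying a dipentylamide and a urea built from two aromatic rings, have been tested for binding. Compound 1 `CCCCCN(CCCCC)C(=O)[C@H]1CCN(C(=O)N(c2ccccc2)c2cccc(Cl)c2)[C@H](C(=O)NCCNCC(N)=O)C1` carries a chloro on one of the urea rings; in an assay on CHO cells for binding affinity to Substance-P receptor (Homo sapiens) (on this read-out lower numbers stand for stronger inhibition and higher numbers for weaker inhibition), compound 1 gives 3.5 nM. Compound 2 `CCCCCN(CCCCC)C(=O)[C@H]1CCN(C(=O)N(c2ccccc2)c2ccccc2)[C@H](C(=O)NCCN(CC(N)=O)Cc2ccccc2OC)C1` lacks that chloro but carries a methoxybenzyl group on its side chain; in this assay compound 2 gives 1.8 nM. The two values lie within the usual scatter of each other, so the data do not tell compound 2 and compound 1 apart.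

Compound 3 `CCCCCN(CCCCC)C(=O)[C@H]1CCN(C(=O)N(c2ccccc2)c2cccc(Cl)c2)[C@H](C(=O)NCCN(CC(N)=O)Cc2ccccc2OC)C1` joins both features. It differs from compound 2 by chloro in place of hydrogen on an aromatic carbon. Going by the values given here, no measured pair shows the effect of that change on its own, so the step from compound 2 to compound 3 is expected to be small, in either direction, as printed in no change at the digits printed from compound 2 to compound 3 (within the scatter). Compound 3 is therefore estimated at 1.8 nM, most likely between 0.8 nM and 4 nM.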

Compound 3, half-maximal inhibitory concentration: 3.8 nM
Compound 3: the middle estimate sits 2.1-fold (0.32 log units) below what was measured, within the range that was stated.
By their numbers in this assay, from the lowest: compounds 2, 1 and 3 (each within the scatter of the next, the first and the last beyond it).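

Swapping phenyl for 3-chlorophenyl on the urea, with the 2-methoxybenzyl group present, is the first change here that can be read on its own: in this assay it gives a 2.1-fold higher number from compound 2 to compound 3 (0.32 log units; beyond the scatter) as a modest step beyond the scatter. Placing 2-methoxybenzyl in place of hydrogen on the amine nitrogen, with the 3-chlorophenyl group present, gives a 1.1-fold higher number from compound 1 to compound 3 (0.04 log units; within the scatter) and so leaves compound 1 and compound 3 indistinguishable in this read-out. Nothing available here explains either step.

Going by these compounds, whether the chloro step would have the same size without the 2-methoxybenzyl group remains open. Also open, on these data alone, is how a fluoro or methoxy group at that ring position, or a plain benzyl group on the amine nitrogen, would compare.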